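Urea for Cyclobutyl Amide on an Isopropyl-Bearing Core

The source may hold more compounds than are shown below. What is called first, only, known or untested is meant among the compounds shown, and "the series" means these compounds.

Three compounds share a core that compound 1 `COc1ccc([N+](=O)[O-])cc1CSc1nc2cc(NC(=O)NC(C)(C)C)ccc2n1Cc1ccccc1` shows, and all were tested in an assay on isolated protein for inhibition of Gonadotropin-releasing hormone receptor (Homo sapiens); on this read-out higher numbers stand for weaker inhibition and lower numbers for stronger inhibition. Compound 1 gives 28 nM. For the measured compounds named here, compound 2 `COc1ccc([N+](=O)[O-])cc1CSc1nc2cc(NC(=O)NC(C)(C)C)ccc2n1Cc1ccccn1` gives 43 nM, and the only single-point step measured, a 1.5-fold higher number from compound 1 to compound 2 (0.19 log units; within the scatter), lies within the scatter. Compound 3 `COc1ccc([N+](=O)[O-])cc1CSc1nc2cc(NC(=O)C3CCC3)ccc2n1C(C)C` gives 1500 nM, the highest number of the three; it stands far beyond the scatter above both compound 2 and compound 1.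

Compound 4 `COc1ccc([N+](=O)[O-])cc1CSc1nc2cc(NC(=O)NC(C)(C)C)ccc2n1C(C)C` arises from compound 3 by (tert-butyl)amino in place of cyclobutyl on a carbonyl carbon. Going by the values given here, no measured step bears directly on this change: compound 3 differs from compound 1 in two places at once, the group on the carbonyl carbon and the group on the aromatic nitrogen, so the contribution of the carbonyl-side change alone cannot be separated. Compound 4 carries the same (tert-butyl)amino urea as compound 1 and compound 2 but keeps the isopropyl of compound 3, so it is expected to land between them, with an 8.3-fold lower number from compound 3 to compound 4 (0.92 log units; beyond the scatter) estimated as a downward step. In this assay compound 4 is expected to give about 180 nM, in a range from 40 nM to 800 nM.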

Compound 4, half-maximal inhibitory concentration: 62 nM
Compound 4: the middle estimate sits 2.9-fold (0.46 log units) above what was measured, and the stated range covers the measured number.
By their numbers in this assay, from the lowest: compounds 1, 2 and 4 (each within the scatter of the next, the first and the last beyond it); then compound 3.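

With the isopropyl on the aromatic nitrogen held fixed, (tert-butyl)amino in place of cyclobutyl on the carbonyl carbon gives in this assay a 24-fold lower number from compound 3 to compound 4 (1.38 log units; beyond the scatter) as a large step, so the group on this carbonyl carbon matters strongly on this core. With the urea kept, the group on the aromatic nitrogen counts for far less: isopropyl in place of (pyridin-2-yl)methyl gives a 1.4-fold higher number from compound 2 to compound 4 (0.16 log units; within the scatter) and stays within the scatter, while isopropyl in place of benzyl gives a 2.2-fold higher number from compound 1 to compound 4 (0.35 log units; beyond the scatter) as a modest step.

From the compounds shown here alone, whether the same carbonyl-side exchange would weigh as heavily with benzyl on the aromatic nitrogen stays open, as does how other groups on the carbonyl carbon, such as dimethylamino or cyclopropyl, would read. The compounds shown offer no measured reason for the size of the carbonyl-side step.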